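The source may report more compounds than this note shows. Statements on the series, on what has been measured and on what is new or still open speak of the compounds shown alone.

Measured compounds:
- compound 1, `CC1CCCC(Oc2cccc3ccc(N)nc23)C1`, 640 nM in an assay on cells with melanin-concentrating hormone receptor 1 (Homo sapiens) as the target, read by radioligand binding; on this read-out lower numbers stand for stronger inhibition and higher numbers for weaker inhibition
- compound 2, `CCC(C)COc1cccc2ccc(N)nc12`, 36 nM in this assay

Of these two, compound 2 stands at the lower number, and compound 1 stands at a higher number, a gap that lies beyond the usual scatter of this kind of measurement. Compound 2 is therefore the stronger of the two measured compounds in this assay.

Compound 3, `Nc1ccc2cccc(OCCC(F)(F)F)c2n1`, has not yet been measured. It keeps the shared core of compound 2 and differs from it in one place: 2,2,2-trifluoroethyl in place of sec-butyl on a saturated chain carbon bound to an oxygen on an aromatic ring. Within the data shown here, no step between two measured compounds shows what such a change does here, so the expectation for compound 3 rests on the structural change alone and on the values of compound 1 and compound 2. A modest step in this assay toward a higher number is expected, though one that may not reach far beyond the scatter. For compound 3 the expected value is 110 nM, with a range from 25 nM to 500 nM, which means an estimated step of a 3.1-fold higher number from compound 2 to compound 3 (0.49 log units; beyond the scatter).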

Compound 3, half-maximal inhibitory concentration: 722 nM
Estimate against measurement, compound 3: 6.6-fold (0.82 log units) below, and the stated range ends below it.
By their numbers in this assay, from the lowest: compound 2; then compounds 1 and 3 (each within the scatter of the next).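

In this assay, the change from sec-butyl to 2,2,2-trifluoroethyl on a saturated chain carbon bound to an oxygen on an aromatic ring gives a 20-fold higher number from compound 2 to compound 3 (1.30 log units; beyond the scatter), which shows that this position responds strongly to what sits at the end of the chain. The two groups count the same in hydrogen-bond donors, hydrogen-bond acceptors, rings and net charge, so none of these counts separates them, and the large step arises from a swap that leaves all of them unchanged. No measured evidence here bears on why the number rises so far.

The compounds shown leave open whether the step follows from the fluorine atoms or from the different shape of the carbon chain, as compound 3 differs from compound 2 in both, and a plain propyl group in the same place, built of carbon and hydrogen only, would pull these two apart. Also open, from the compounds shown here alone, is how this position would respond to a group of another kind at the chain end, such as an amine or a carboxylic acid, or to a longer unbranched chain.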